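From 4-butylphenyl to butyl on the triple bond

A few compounds are considered here, and "the series" means these few. Any claim that something is new, unique, unknown or untested is made for them only; others in the source may bear on it.

In an ADME assay on WI-38 cells (Homo sapiens) for cytotoxicity, read by MTT assay, with a stated time of 3 days (on this read-out lower numbers stand for stronger inhibition and higher numbers for weaker inhibition), compound 1 (`CCCCCc1ccc(C#Cc2cn(C/C=C/CN3C(=O)c4ccccc4C3=O)c(=O)[nH]c2=O)cc1`) gives 25000 nM and compound 2 (`CCCCc1ccc(C#Cc2cn(C/C=C/CN3C(=O)c4ccccc4C3=O)c(=O)[nH]c2=O)cc1`) gives 40000 nM. Going by the values given here, these two numbers lie within the scatter of each other, so compound 2 stands level with its only measured neighbour.

Compound 3 (`CCCCC#Cc1cn(C/C=C/CN2C(=O)c3ccccc3C2=O)c(=O)[nH]c1=O`) differs from compound 2 at one place, with butyl in place of 4-butylphenyl on a triple-bonded carbon.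

Among the compounds with values here, only one measured step bears on this change. That step, a 1.6-fold higher number from compound 1 to compound 2 (0.20 log units; within the scatter), replaces methyl with hydrogen on a saturated chain carbon and stays within the scatter. It touches only the end of the chain, whereas compound 3 loses the whole six-membered aromatic ring of carbon. Within the data shown here, no measured pair covers such a loss, so the step is a weak guide to both size and direction.

A modest move towards a higher number is expected, with wide uncertainty, and the estimated size is a 1.5-fold higher number from compound 2 to compound 3 (0.18 log units; within the scatter). The estimate for compound 3 is 60000 nM, with an expected range of 25000 nM to 140000 nM.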

Compound 3, half-maximal inhibitory concentration: 35000 nM
Estimate against measurement, compound 3: 1.7-fold (0.23 log units) above; measured number inside the range.
By their numbers in this assay, from the lowest: compounds 1, 3 and 2 (each within the scatter of the next).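

On the triple-bonded carbon, butyl in place of 4-butylphenyl gives in this assay a 1.1-fold lower number from compound 2 to compound 3 (0.06 log units; within the scatter) and butyl in place of 4-pentylphenyl gives a 1.4-fold higher number from compound 1 to compound 3 (0.15 log units; within the scatter) at the same place. The earlier pair touched only the end of the chain on the aromatic ring, whereas these steps take away the whole six-membered aromatic ring of carbon, going from the 10 heavy atoms of 4-butylphenyl to the 4 heavy atoms of butyl, and all three compounds still stay within the scatter of each other, so for these compounds neither the ring nor the chain length at this place separates the numbers. No measurement is at hand that would explain this result.

On these data alone, what an amine, a carboxylic acid or a chain longer than butyl would do on the triple-bonded carbon stays open. As far as these compounds go, with only hydrocarbon groups at this place and no step beyond the scatter, it is also open which replacement here, if any, would move the number clearly away from these three compounds.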